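This account rests on a few compounds, and the source may have more. Where it says the series, first, only, none or still open, it means among the compounds named here.

Measured compounds in the series:

Compound 1, `COc1cc(Nc2ncnc3c(NC(=O)Nc4ccccc4Cl)cccc23)cc(OC)c1`: 356 nM
Compound 2, `COc1cc(Nc2ncnc3c(NC(=O)Nc4ccc(F)cc4C(F)(F)F)cccc23)cc(OC)c1`: 2970 nM
Compound 3, `COc1cc(Nc2ncnc3c(NC(=O)Nc4ccc(Cl)cc4)cccc23)cc(OC)c1`: 2490 nM

In a functional assay on RT-112 cells (Homo sapiens) for antiproliferative activity, read by MTT assay, with a stated time of 72 h (on this read-out lower numbers stand for stronger inhibition of growth and higher numbers for weaker inhibition of growth), compound 1 stands lowest of the three numbers. Its nearest neighbour is compound 3, reached by a 7.0-fold higher number from compound 1 to compound 3 (0.84 log units; beyond the scatter); the furthest is compound 2, reached by an 8.3-fold higher number from compound 1 to compound 2 (0.92 log units; beyond the scatter). Compounds 2 and 3 sit close together, as a 1.2-fold lower number from compound 2 to compound 3 (0.08 log units; within the scatter) shows.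

Compound 4, `COc1cc(Nc2ncnc3c(NC(=O)Nc4ccc(F)cc4F)cccc23)cc(OC)c1`, is not yet measured. It differs from compound 1 in one place: 2,4-difluorophenyl in place of 2-chlorophenyl on an amide-type nitrogen.

Among the measured compounds shown here, two measured steps bear on this change, and both start from compound 1 by replacing the 2-chlorophenyl on the amide-type nitrogen. Swapping it for 4-fluoro-2-(trifluoromethyl)phenyl gave an 8.3-fold higher number from compound 1 to compound 2 (0.92 log units; beyond the scatter), and swapping it for 4-chlorophenyl gave a 7.0-fold higher number from compound 1 to compound 3 (0.84 log units; beyond the scatter). Both replacements moved the number up beyond the scatter, by a modest amount. The 2,4-difluorophenyl of compound 4 is a third replacement of the same group, so a higher number than compound 1 is expected, though the two precedents leave it uncertain whether the loss is as large as in compounds 2 and 3.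

Compound 4 is therefore estimated at 1300 nM, with a range of 450 nM to 3800 nM, which means an expected step of a 3.7-fold higher number from compound 1 to compound 4 (0.56 log units; beyond the scatter).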

Compound 4, concentration for 50% growth inhibition: 2460 nM
The estimate for compound 4 lay 1.9-fold (0.28 log units) below the measured number, and the stated range covers the measured number.
By their numbers in this assay, from the lowest: compound 1; then compounds 4, 3 and 2 (each within the scatter of the next).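

In this assay, among the compounds shown here, the 2,4-difluorophenyl group on the amide-type nitrogen gives a 6.9-fold higher number from compound 1 to compound 4 (0.84 log units; beyond the scatter) and so joins the two earlier replacements, which leaves compound 1 with its 2-chlorophenyl as the only compound of the four at the low end of the series. The three replacements do not separate from one another: the step from 4-chlorophenyl gives a 1.0-fold lower number from compound 3 to compound 4 (0.01 log units; within the scatter) and fluoro in place of trifluoromethyl on an aromatic carbon gives a 1.2-fold lower number from compound 2 to compound 4 (0.08 log units; within the scatter) with neither change moving the number beyond the usual scatter. Nothing available on these compounds accounts for the distance between compound 1 and the other three.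

From the compounds shown here alone, it remains open whether the stronger inhibition of growth belongs to 2-chlorophenyl specifically or extends to close relatives such as 2-bromophenyl, 2-methylphenyl or 2-methoxyphenyl, and where unsubstituted phenyl would fall relative to this series. The compounds shown also leave open how far the pattern holds on other parts of the molecule, since the core of compound 1 and its two methoxy groups stay the same throughout, and whether a 3-chlorophenyl or a 2,6-dichlorophenyl would stand with compound 1 or with the other three.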